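The source may report more compounds than this note shows. Statements on the series, on what has been measured and on what is new or still open speak of the compounds shown alone.

Three compounds share one core and differ only in a single group on the outer six-membered ring. Compound 1 `Cc1cccc(COc2ccc3occc(=O)c3c2)c1` carries a methyl, and in an assay on microsomes for inhibition of Amine oxidase [flavin-containing] A (Homo sapiens), read by fluorescence and spectrophotometry, with a stated time of 20 min (a lower number here means a stronger inhibitor, a higher number a weaker inhibitor), compound 1 gives 1130 nM. Compound 2 `Cc1ccc(COc2ccc3occc(=O)c3c2)cc1` has the same atoms joined differently; the difference between the two cores is not broken down here. In this assay compound 2 gives 3490 nM, the highest of the three numbers, beyond the scatter from compound 1 and further still from compound 3. Compound 3 `N#Cc1cccc(COc2ccc3occc(=O)c3c2)c1` carries a cyano in place of the methyl, and in this assay compound 3 gives 255 nM.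

Among the compounds with values here, the single measured step is cyano in place of methyl on an aromatic carbon, which gave a 4.4-fold lower number from compound 1 to compound 3 (0.65 log units; beyond the scatter). Compound 4 `N#Cc1ccc(COc2ccc3occc(=O)c3c2)cc1`, not yet measured in this assay, is made from compound 2 by cyano in place of methyl on an aromatic carbon. The two changes are the same kind of change but not the same: in compound 3 the cyano sits meta to a large group, in compound 4 para to a large group, and the changed ring itself differs between the two cores, whose difference is not broken down here.

Resting on the step from compound 1 to compound 3 a 4.4-fold lower number from compound 1 to compound 3 (0.65 log units; beyond the scatter), and allowing for the different place, compound 4 is expected to show a 3.9-fold lower number from compound 2 to compound 4 (0.59 log units; beyond the scatter). Compound 4 is estimated at 900 nM, between 350 nM and 2500 nM, in this assay.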

Compound 4, half-maximal inhibitory concentration: 175 nM
Beside the measured number, compound 4's estimate is 5.1-fold (0.71 log units) above it, and the stated range ends above it.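

In this assay, cyano in place of methyl on an aromatic carbon, para to a large group, gave a 20-fold lower number from compound 2 to compound 4 (1.30 log units; beyond the scatter), and the size of this step does not match that of the same change on the other core: the same change on two cores in this assay, a 4.4-fold lower number (0.65 log units; beyond the scatter) from compound 1 to compound 3 and a 20-fold lower number (1.30 log units; beyond the scatter) from compound 2 to compound 4, 4.5-fold (0.65 log units) apart, beyond the scatter of two such steps What this shows is that the direction of the change held in both pairs, with the cyano compound giving the lower number each time, while the size of the step did not carry over from one core to the other. It does not show what sets the two steps apart, since the two pairs differ both in where the group sits and in the core, and two pairs cannot separate these, so a step measured on one core in this series gives the likely direction on the other but not a reliable size.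

The compounds shown leave open whether an amine, a carboxylic acid or a longer chain in place of the methyl would follow the same direction on both cores. They also leave open whether the gap between the two steps would recur with any group other than cyano, such as a chlorine or a methoxy group.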